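The source may report more compounds than this note shows. Statements on the series, on what has been measured and on what is new or still open speak of the compounds shown alone.

Compound 1 `Cc1nn(C(=O)C2CCCCC2)c(N)c1-c1ccc(Cl)c(Cl)c1` gives 3300 nM in an assay on Sf9 cells for inhibition of mitogen-activated protein kinase kinase kinase 14 (Homo sapiens), read by ADP-Glo, with a stated time of 60 min; on this read-out lower numbers stand for stronger inhibition and higher numbers for weaker inhibition. Compound 2 `Cc1nn(C(=O)OC(C)(C)C)c(N)c1-c1ccc(Cl)c(Cl)c1` is reported in this assay only as a limit, > 100000 nM. The step of an at least 30-fold higher number from compound 1 to compound 2 (1.48 log units; beyond the scatter) is therefore known only as a bound, set by the limit of > 100000 nM in this assay, at which 1 of the 2 values shown sits. Compound 3 `CCNC(=O)n1nc(C)c(-c2ccc(Cl)c(Cl)c2)c1N` differs from compound 2 by ethylamino in place of tert-butoxy on a carbonyl carbon. Among the measured compounds shown here, only that single step bears on the change at this carbonyl, and it was large in the weakening direction, so some recovery toward compound 1 is expected but uncertain. Compound 3 is estimated at 20000 nM, between 3000 nM and 100000 nM. This means an expected step of an at least 5.0-fold lower number from compound 2 to compound 3 (0.69 log units; beyond the scatter).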

Compound 3, half-maximal inhibitory concentration: > 100000 nM
Compound 3: no number, only a limit (the forecaster's own chance of this, stated with the estimate: 35%); at least 5.0-fold (0.69 log units) between middle value and limit.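

Ethylamino on the carbonyl carbon gives, in this assay, an at least 30-fold higher number from compound 1 to compound 3 (1.48 log units; beyond the scatter), so a second replacement of cyclohexyl ends without a readable number. Compound 3 is reported only as a limit, and so the change from an oxygen-linked to a nitrogen-linked group at this carbonyl shows no recovery toward compound 1. The step between compound 2 and compound 3 cannot be read: the limit of > 100000 nM in this assay, at which 2 of the 3 values shown sit.

Going by these compounds, whether cyclopentyl, phenyl or a longer chain on this carbonyl carbon would keep a readable number stays open. So does whether a larger amine such as cyclohexylamino would do so.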